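The source may hold more compounds than are shown below. What is called first, only, known or untested is meant among the compounds shown, and "the series" means these compounds.

Measured so far:
compound 1, `CCc1cccc(NC(=O)CN2CCC(c3cccc[n+]3[O-])CC2)c1`, 62%;
compound 2, `O=C(CN1CCC(c2cccc[n+]2[O-])CC1)Nc1ccc(F)cc1F`, 74%;
compound 3, `Cc1cc(Br)ccc1NC(=O)CN1CCC(c2cccc[n+]2[O-])CC1`, 61%.

In a functional assay on HEK293 cells for agonist activity at D(4) dopamine receptor (Homo sapiens), read by FLIPR (on this read-out lower numbers stand for smaller maximal responses and higher numbers for larger maximal responses), compound 1 gives 62%, the second highest of the three numbers: compound 3 lies within the scatter of it, whereas the step of a number 12 percentage points higher from compound 1 to compound 2 (beyond the scatter) goes beyond the scatter. Compound 4 `O=C(CN1CCC(c2cccc[n+]2[O-])CC1)Nc1cccc(OC(F)(F)F)c1` differs from compound 1 by one change: trifluoromethoxy in place of ethyl on an aromatic carbon. Within the data shown here, none of the measured steps swaps a single group on one ring carbon; the steps from compound 1 exchange the whole aryl group, with sizes a number 12 percentage points higher from compound 1 to compound 2 (beyond the scatter) and a number 1 percentage points lower from compound 1 to compound 3 (within the scatter). Both stayed modest, so a modest step at most, in no clear direction, is expected here. Compound 4 is therefore estimated at 65%, between 54% and 78%, an expected step of a number 3 percentage points higher from compound 1 to compound 4 (within the scatter).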

Compound 4, largest response reached (reported as efficacy), in percent of the reference or control that the assay uses: 51%
For compound 4 the middle estimate is 14 percentage points above the measured one; the measured number lies below the stated range.
By their numbers in this assay, from the lowest: compounds 4, 3 and 1 (each within the scatter of the next, the first and the last beyond it); then compound 2.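

The earlier steps shown here from compound 1 exchanged the whole aryl group, whereas this one changes a single group on an aromatic carbon, meta to a large group. In this assay, trifluoromethoxy in place of ethyl gives a number 11 percentage points lower from compound 1 to compound 4 (beyond the scatter), so this one change alone can lower the maximal response by more than the scatter. Nothing measured here explains the drop.

Going by these compounds, whether a methoxy group, an amine or a carboxylic acid on the same carbon would lower the response as well remains open. Also open, on these data alone, is whether trifluoromethoxy would act the same way on the aryl groups of compound 2 or compound 3.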